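Compound 3 to compound 4: a butoxycarbonyl step

This account rests on a few compounds, and the source may have more. Where it says the series, first, only, none or still open, it means among the compounds named here.

Values in a functional assay on the whole organism with Rattus norvegicus as the target; on this read-out lower numbers stand for an effect already at smaller amounts and higher numbers for an effect only at larger amounts of compound
compound 1 `O=C(O)c1cc(-c2ccccc2)ccc1O` gives 54 mg/kg
compound 2 `O=C(O)c1ccc(-c2ccccc2)cc1O` gives 150 mg/kg
compound 3 `O=C(O)c1cc(-c2ccc(F)cc2)ccc1O` gives 14 mg/kg

Compound 3 has the lowest number of the three, beyond the scatter from both others. Compound 4 `CCCCOC(=O)Oc1ccc(-c2ccc(F)cc2)cc1C(=O)O` carries butoxycarbonyl in place of hydrogen on an oxygen on an aromatic ring. Among the measured compounds shown here, the one measured step, fluoro in place of hydrogen on an aromatic carbon, gave a 3.9-fold lower number from compound 1 to compound 3 (0.59 log units; beyond the scatter) at another place, so it offers no size for this change. In this assay no step beyond the scatter is therefore expected, and no direction is favoured. The expected step is a 1.1-fold higher number from compound 3 to compound 4 (0.03 log units; within the scatter) (an estimate). The estimated value for compound 4 is 15 mg/kg with an expected range from 6 mg/kg to 40 mg/kg (end of estimate).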

Compound 4, dose for half-maximal effect: 25 mg/kg
The estimate for compound 4 lay 1.7-fold (0.22 log units) below the measured number; measured number inside the range.
By their numbers in this assay, from the lowest: compounds 3 and 4 (each within the scatter of the next); then compound 1; then compound 2.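

Among the compounds shown here, this is the first change on the oxygen on the aromatic ring rather than on an aromatic carbon: hydroxy to (butoxycarbonyl)oxy gives a 1.8-fold higher number from compound 3 to compound 4 (0.25 log units; within the scatter) in this assay and so leaves compound 3 and compound 4 indistinguishable. A free hydroxy on this oxygen is therefore not required for a number in this range on the read-out of the whole animal. No available data explain this result.

Still open, from the compounds shown here alone, is whether a shorter acetyl group or a longer octyloxycarbonyl chain on the same oxygen would read the same way. Going by these compounds, it is also open whether butoxycarbonyl behaves alike on the core of compound 1, which lacks the fluoro.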